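A Dichlorophenyl Sulfonyl Variant of an Inactive Hydrazide

The compounds below may be only part of what the source reports. "The series", "measured", "known", "first", "only" and "open" are said of these compounds alone.

Measured compounds:
compound 1, `CC(=O)Nc1ccc(S(=O)(=O)NNC(=O)c2cccnc2Nc2ccc(Cl)cc2)cc1`, > 100000 nM
compound 2, `O=C(NNS(=O)(=O)c1ccc(F)cc1)c1cccnc1Nc1ccc(Cl)cc1Cl`, > 100000 nM

Of the compounds shown here, two have been tested in a functional assay on COLO 205 cells (Homo sapiens) for antiproliferative activity; on this read-out higher numbers stand for lower toxicity in this test and lower numbers for higher toxicity in this test. For compound 1 the result is only a limit, > 100000 nM, so no number is known for it. Compound 2 likewise gives only the limit > 100000 nM. Compound 1 thus stands at the limit of > 100000 nM in this assay, at which 2 of the 2 values shown sit, and the two results cannot be ranked against each other.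

Compound 3, `O=C(NNS(=O)(=O)c1ccc(Cl)cc1Cl)c1cccnc1Nc1ccc(Cl)cc1`, differs from compound 1 by 2,4-dichlorophenyl in place of 4-acetamidophenyl on a sulfonyl sulfur, in words: 2,4-dichlorophenyl in place of 4-acetamidophenyl on a sulfonyl sulfur. For the measured compounds named here, no step between two measured compounds is known, so there is no measured size to lean on. Compound 1 reached only the limit > 100000 nM. Compound 3 is therefore expected to stay near that limit as well, with an expected step that the limit leaves unreadable from compound 1 to compound 3 of no clear direction beyond the scatter. In this assay compound 3 is expected at 150000 nM, within 50000 nM to 500000 nM, most likely again reported only as a limit.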

Compound 3, concentration lethal to 50% of the cells: 49000 nM
Compound 3: the middle estimate sits 3.1-fold (0.49 log units) above what was measured, outside the stated range (below it).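

In this assay compound 3 gives 49000 nM, the only number among the compounds shown, so a change of group on the sulfonyl sulfur can bring the result within readable range. Putting 2,4-dichlorophenyl in place of 4-acetamidophenyl at this place gives an at least 2.0-fold lower number from compound 1 to compound 3 (0.30 log units; that floor lies within the scatter); this step is known only as a floor, and because that floor lies within the scatter, its true size remains uncertain. The other two results are limits and not numbers: the limit of > 100000 nM in this assay, at which 2 of the 3 values shown sit.

As far as these compounds go, it remains open whether a phenyl group carrying a single chlorine, or a methoxy group, on the sulfonyl sulfur would also give a number. Which feature of the 2,4-dichlorophenyl group lies behind the step also stays unresolved.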